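Furan-amide sulfamates: aryl substitution on the amide nitrogen

The source may hold more compounds than are shown below. What is called first, only, known or untested is meant among the compounds shown, and "the series" means these compounds.

Measured compounds:
compound 1 `Cc1cccc(F)c1N(C)C(=O)c1ccc(-c2ccc(OS(N)(=O)=O)cc2)o1`, 150 nM
compound 2 `Cc1cc(F)ccc1N(C)C(=O)c1ccc(-c2ccc(OS(N)(=O)=O)cc2)o1`, 14 nM
compound 3 `Cc1c(F)cccc1N(C)C(=O)c1ccc(-c2ccc(OS(N)(=O)=O)cc2)o1`, 27 nM

In an assay on T47D cells for inhibition of Steryl-sulfatase (Homo sapiens), read by HPLC, with a stated time of 24 h (a lower number here means a stronger inhibitor, a higher number a weaker inhibitor), compound 3 stands second highest of the three numbers. Its nearest neighbour is compound 2, with a 1.9-fold higher number from compound 2 to compound 3 (0.29 log units; within the scatter), a gap within the scatter. Its furthest is compound 1, with a 5.6-fold lower number from compound 1 to compound 3 (0.74 log units; beyond the scatter); the parallel step an 11-fold lower number from compound 1 to compound 2 (1.03 log units; beyond the scatter) points the same way.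

Compound 4 `Cc1ncccc1N(C)C(=O)c1ccc(-c2ccc(OS(N)(=O)=O)cc2)o1` is not yet measured. It differs from compound 3 in one place: 2-methylpyridin-3-yl in place of 3-fluoro-2-methylphenyl on an amide-type nitrogen. Within the data shown here, no measured step exchanges a carbon-only ring for a pyridine ring, so nothing bears directly on this change. The measured steps all concern where a fluorine sits on a 2-methylphenyl group, and between compounds 2 and 3 that move stayed within the scatter. Compound 4 keeps a 2-methyl group in its name and loses the fluorine entirely, so the expected step is small: a step of a 1.5-fold higher number from compound 3 to compound 4 (0.17 log units; within the scatter) is expected in this assay, not beyond the scatter. For compound 4 the estimate in this assay is 40 nM, in the range 12 nM to 130 nM.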

Compound 4, half-maximal inhibitory concentration: 270 nM
For compound 4 the middle estimate is 6.8-fold (0.83 log units) below the measured one; the whole stated range lies below it.
By their numbers in this assay, from the lowest: compounds 2 and 3 (each within the scatter of the next); then compounds 1 and 4 (each within the scatter of the next).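

Replacing the carbon-only ring on the amide-type nitrogen with a pyridine ring is not a neutral exchange in this assay: the series shows a 10-fold higher number from compound 3 to compound 4 (1.00 log units; beyond the scatter) and a 19-fold higher number from compound 2 to compound 4 (1.29 log units; beyond the scatter) on this change, whereas moving the fluorine between compounds 2 and 3 stayed within the scatter. The 2-methylpyridin-3-yl group also lands with the 2-fluoro-6-methylphenyl group, with a 1.8-fold higher number from compound 1 to compound 4 (0.26 log units; within the scatter) as the only gap, so two quite different changes at this position end at a similar number. Nothing available speaks to what lies behind these steps.

Compound 4 gains a ring nitrogen and loses the fluorine in one exchange, so the two contributions cannot be told apart; a plain 2-methylphenyl group on the amide-type nitrogen would separate them. Also open, on these data alone, is whether a 2-methylpyridin-3-yl group that keeps a fluorine would recover any of the difference.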